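The source may report more compounds than this note shows. Statements on the series, on what has been measured and on what is new or still open speak of the compounds shown alone.

Compounds measured:
compound 1 `CCOCCn1c(N2CCN(C)CC2)nc2ccccc21`, 10 nM in a functional assay on ileum for inhibition of histamine H1 receptor (Cavia porcellus); on this read-out lower numbers stand for stronger inhibition and higher numbers for weaker inhibition
compound 2 `CCOCCn1c(N2CCN(CC)CC2)nc2ccccc21`, 18 nM
compound 3 `CCCN1CCN(c2nc3ccccc3n2CCOCC)CC1`, 16 nM

In this assay compound 1 gives the lowest of the three numbers, though its gaps to the others, a 1.8-fold higher number from compound 1 to compound 2 (0.26 log units; within the scatter) and a 1.6-fold higher number from compound 1 to compound 3 (0.20 log units; within the scatter), both sit within the scatter, as does a 1.1-fold lower number from compound 2 to compound 3 (0.05 log units; within the scatter). Compound 4 `CCCCCCCn1c(N2CCN(C)CC2)nc2ccccc21` differs from compound 1 by pentyl in place of ethoxy on a saturated chain carbon, two bonds along the chain from an aromatic nitrogen. None of the three measured steps touches that part of the molecule; each alters only the group on the amine nitrogen in the ring, and each stayed within the scatter. The data therefore give no direct guide, and the expectation is a step of a 1.5-fold higher number from compound 1 to compound 4 (0.18 log units; within the scatter), not beyond the scatter. Compound 4 is estimated at 15 nM, between 4 nM and 60 nM.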

Compound 4, half-maximal inhibitory concentration: 150 nM
The estimate for compound 4 lay 10-fold (1.00 log units) below the measured number; the measured number lies above the stated range.
By their numbers in this assay, from the lowest: compounds 1, 3 and 2 (each within the scatter of the next); then compound 4.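

In this assay, pentyl in place of ethoxy on a saturated chain carbon, two bonds along the chain from an aromatic nitrogen, gives a 15-fold higher number from compound 1 to compound 4 (1.18 log units; beyond the scatter). This position therefore responds far more strongly than the group on the amine nitrogen in the ring, where every earlier step stayed within the scatter. The change swaps oxygen for carbon and also adds heavy atoms, and this single step cannot separate the two, while nothing available explains its size.

Going by these compounds, it remains open whether methoxy, a terminal hydroxyl or an amine on this chain would restore a number close to that of compound 1. Whether a shorter all-carbon chain would do so also remains unresolved.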